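Chloro for trifluoromethyl on the open urea aryl

A few compounds are considered here, and "the series" means these few. Any claim that something is new, unique, unknown or untested is made for them only; others in the source may bear on it.

Compound 1 `COc1cc(NC(C)CCCNC(=O)NNC(=O)Nc2ccc(Br)cc2)c2ncccc2c1` gives 100 nM in a functional assay on MCF7 cells (Homo sapiens) for inhibition, read by MTT assay, with a stated time of 72 h; a lower number here means a stronger inhibitor, a higher number a weaker inhibitor.
Compound 2 `COc1cc(NC(C)CCCNC(=O)Nc2ccc(C(F)(F)F)cc2)c2ncccc2c1` gives 1900 nM.
Compound 3 `COc1cc(NC(C)CCCNC(=O)NNC(=O)Nc2ccc(Cl)cc2)c2ncccc2c1` gives 180 nM.

Compound 2 stands highest of the three and is the weakest inhibitor: the steps of a 19-fold higher number from compound 1 to compound 2 (1.28 log units; beyond the scatter) and an 11-fold lower number from compound 2 to compound 3 (1.02 log units; beyond the scatter) are both large, but each combines a change at the aromatic carbon with ((4-bromophenyl)carbamoyl)amino or ((4-chlorophenyl)carbamoyl)amino in place of an aryl on an amide-type nitrogen, so neither isolates the aryl substituent. Compound 4 `COc1cc(NC(C)CCCNC(=O)Nc2ccc(Cl)cc2)c2ncccc2c1` differs from compound 2 by chloro in place of trifluoromethyl on an aromatic carbon. Going by the values given here, the only measured step confined to that aromatic carbon is a 1.8-fold higher number from compound 1 to compound 3 (0.26 log units; within the scatter), within the scatter. Among the compounds with values here, no measured step exchanges trifluoromethyl for a halogen. Compound 4 is therefore expected to give 1500 nM (range 600 nM to 4000 nM). The expected step of a 1.3-fold lower number from compound 2 to compound 4 (0.10 log units; within the scatter) is estimated to stay within the scatter.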

Compound 4, half-maximal inhibitory concentration: 12000 nM
Estimate against measurement, compound 4: 8.0-fold (0.90 log units) below, and the stated range ends below it.
By their numbers in this assay, from the lowest: compounds 1 and 3 (each within the scatter of the next); then compound 2; then compound 4.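

On the open urea aryl, this aromatic carbon responds to the swap: chloro in place of trifluoromethyl moves this assay beyond the scatter (a 6.3-fold higher number from compound 2 to compound 4 (0.80 log units; beyond the scatter)), whereas bromo to chloro on the extended compounds stayed within it. Losing the carbamoylamino extension matters more, both with chloro kept (a 67-fold higher number from compound 3 to compound 4 (1.82 log units; beyond the scatter)) and with bromo exchanged as well (a 120-fold higher number from compound 1 to compound 4 (2.08 log units; beyond the scatter)). Nothing available explains either step. Open, from the compounds shown here alone, is where an amine or a carboxylic acid on that aromatic carbon would fall relative to trifluoromethyl and chloro. Also open, going by these compounds, is whether trifluoromethyl keeps its edge over chloro on the extended chain.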